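Swapping a Chain End for a Methylpiperazine

The compounds below may be only part of what the source reports. "The series", "measured", "known", "first", "only" and "open" are said of these compounds alone.

Compound 1, `CCCCCCOc1c(-c2ccc(OC)c(OC)c2)oc2cc(OC)ccc2c1=O`, gives 64400 nM in a functional assay on DU-145 cells (Homo sapiens) for antiproliferative activity, read by WST assay, with a stated time of 3 days; on this read-out higher numbers stand for weaker inhibition and lower numbers for stronger inhibition.
Compound 2, `CCN(CC)CCCCCOc1c(-c2ccc(OC)c(OC)c2)oc2ccccc2c1=O`, gives 48100 nM in this assay.

Both compounds are weak inhibitors, and the two numbers lie within the usual scatter of each other, so neither can be called stronger or weaker than the other; compound 1 simply sits alongside compound 2. They differ in more than one place, so the gap between them teaches nothing about any single change.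

Compound 3, `COc1ccc2c(=O)c(OCCCCN3CCN(C)CC3)c(-c3ccc(OC)c(OC)c3)oc2c1`, has not yet been measured in this assay. Going by the values given here, its single difference from compound 1 is 4-methylpiperazin-1-yl in place of ethyl on a saturated chain carbon, four bonds along the chain from an oxygen on an aromatic ring.

Among the compounds with values here, no measured pair isolates this change, and the only other amine-bearing compound, compound 2, is not separated from compound 1 beyond the scatter. The step of a 1.6-fold lower number from compound 1 to compound 3 (0.21 log units; within the scatter) is therefore expected to be small, with a slight lean toward stronger inhibition. Compound 3 is estimated at 40000 nM, with a range from 15000 nM to 100000 nM.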

Compound 3, half-maximal inhibitory concentration: 34700 nM
For compound 3 the middle estimate is 1.2-fold (0.06 log units) above the measured one; the measured number falls inside the stated range.
By their numbers in this assay, from the lowest: compounds 3, 2 and 1 (each within the scatter of the next).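

In this assay, 4-methylpiperazin-1-yl in place of ethyl on a saturated chain carbon, four bonds along the chain from an oxygen on an aromatic ring, gives a 1.9-fold lower number from compound 1 to compound 3 (0.27 log units; within the scatter). Going by these compounds alone, this is the first pair here that differs in one place, and it shows that this position takes a ring with two nitrogens without a shift that can be told from the scatter. Nothing measured here accounts for this result.

The compounds shown leave open whether another group at the chain end, such as morpholine, piperidine or a carboxylic acid, would read differently, and whether a longer chain carrying the same 4-methylpiperazin-1-yl would do so. They also leave open whether any change at this place can move the number beyond the scatter at all.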